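From methyl to benzyloxy: a forecast for compound 4

The compounds below may be only part of what the source reports. "The series", "measured", "known", "first", "only" and "open" are said of these compounds alone.

- compound 1 `CC(=O)N1N=C(c2ccc3ccccc3c2)OC1c1ccc(Cl)cc1`: 2.48 ug/mL
- compound 2 `CC(=O)N1N=C(c2ccc3ccccc3c2)OC1c1ccc([N+](=O)[O-])cc1`: 9.32 ug/mL
- compound 3 `CC(=O)N1N=C(c2ccc3ccccc3c2)OC1c1ccc(C)cc1`: 3.85 ug/mL

In a functional assay on B16-F10 cells (Mus musculus) for antiproliferative activity, read by MTT assay, with a stated time of 48 h (on this read-out higher numbers stand for weaker inhibition and lower numbers for stronger inhibition), compound 3 gives 3.85 ug/mL. Its nearest neighbour is compound 1 at 2.48 ug/mL, and the gap, a 1.6-fold higher number from compound 1 to compound 3 (0.19 log units; within the scatter), is no real difference. Compound 2 stands apart at 9.32 ug/mL, and the step back is a 2.4-fold lower number from compound 2 to compound 3 (0.38 log units; beyond the scatter).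

The next compound to test is compound 4 `CC(=O)N1N=C(c2ccc3ccccc3c2)OC1c1ccc(OCc2ccccc2)cc1`. It keeps the shared core of compound 3 and changes one group: benzyloxy in place of methyl on an aromatic carbon. This puts benzyloxy in place of methyl on an aromatic carbon, para to a large group.

For the measured compounds named here, all three measured steps are swaps at this same place, so they are the only guide. The largest, a 3.8-fold higher number from compound 1 to compound 2 (0.57 log units; beyond the scatter), is modest, and the swap from chloro to methyl moved nothing beyond the scatter. Going by the values given here, none of the measured compounds carries a group with a ring there, so this forecast is an extrapolation and its range must stay wide. The expected result in this assay is no step beyond the scatter: the estimated change is a 1.2-fold higher number from compound 3 to compound 4 (0.07 log units; within the scatter). Compound 4 is estimated at 4.5 ug/mL, with an expected range of 1.6 ug/mL to 12 ug/mL.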

Compound 4, half-maximal inhibitory concentration: 8.08 ug/mL
For compound 4 the middle estimate is 1.8-fold (0.25 log units) below the measured one; the range from low to high includes it.
By their numbers in this assay, from the lowest: compounds 1 and 3 (each within the scatter of the next); then compounds 4 and 2 (each within the scatter of the next).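

Benzyloxy is the first group with a ring at this place, and in this assay the swap from methyl gives a 2.1-fold higher number from compound 3 to compound 4 (0.32 log units; beyond the scatter) as a real but modest loss, so a ring here does not abolish the effect on these cells. Benzyloxy, with its ring, and nitro, without one, cannot be told apart, with a 1.2-fold lower number from compound 2 to compound 4 (0.06 log units; within the scatter) as the printed step, while the swap from chloro gives a 3.3-fold higher number from compound 1 to compound 4 (0.51 log units; beyond the scatter) and leaves the four compounds in two groups, chloro with methyl and nitro with benzyloxy. The data offer no measurement that accounts for this grouping, so the steps stand here as observations only.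

Benzyloxy differs from methyl by both an oxygen and a ring, and the compounds shown cannot say which of the two goes with the step; methoxy, which keeps the oxygen without the ring, and phenyl, which keeps the ring without the oxygen, would begin to separate them. From the compounds shown here alone, what an amine or a carboxylic acid would do on this same aromatic carbon also remains open.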